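The source may report more compounds than this note shows. Statements on the series, on what has been measured and on what is new or still open speak of the compounds shown alone.

The series shares a dienone lactam core bearing a dimethoxyphenyl group; compound 1 is `COc1ccc(/C=C/C2CC=CC(=O)N2)c(OC)c1` and compound 2 is `COc1ccc(/C=C/C2CC=CC(=O)N2)cc1OC`. Growth of HaCaT cells is read by an ADME assay on HaCaT cells (Homo sapiens) for inhibition, read by sulforhodamine B assay, with a stated time of 48 h; a lower number here means a stronger inhibitor of growth, a higher number a weaker inhibitor of growth. In this assay compound 1 reports only a limit, > 964 uM. In this assay compound 2 likewise reports only a limit, > 964 uM. For the measured compounds named here, compound 2 thus stands at the limit, together with compound 1, as summarised by the limit of > 964 uM in this assay, at which 2 of the 2 values shown sit; neither gives a number, so no step between the two can be measured.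

Compound 3 is `COc1cc(OC)c(OC)cc1/C=C/C1CC=CC(=O)N1`. It differs from compound 2 by methoxy in place of hydrogen on an aromatic carbon. With both neighbours sitting at the limit, a small added methoxy is expected to leave compound 3 in the same region, the step from compound 2 to compound 3 being expected as a step that the limit leaves unreadable from compound 2 to compound 3, that is none beyond the scatter. Compound 3 is accordingly estimated at 1500 uM in this assay, with a range from 700 uM to 3500 uM, and most likely it too will return only a limit rather than a number.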

Compound 3, concentration for growth inhibition (reported as GI): > 864 uM
Compound 3 ended at the assay's limit; the forecaster's own chance of this, stated with the estimate: 80%; the middle value lies beyond the limit too.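

Compound 3, like compound 1 and compound 2, returns only a limit in this assay, so the steps from compound 2 to compound 3 and from compound 1 to compound 3 cannot be read. The three compounds shown leave open what their growth inhibition is as a number, and whether methoxy in place of hydrogen on an aromatic carbon changes it at all.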